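Allyl to Methoxybenzyl Sulfide: Gastric Cancer Cell Inhibition

The compounds below may be only part of what the source reports. "The series", "measured", "known", "first", "only" and "open" are said of these compounds alone.

Compound 1 `C=CCSc1nc2nc(C)cc(N3CC[C@@H](C)[C@@H](N(C)c4ncnc5[nH]ccc45)C3)n2n1` carries an allylsulfanyl group on the shared core. In a functional assay on HGC-27 cells (Homo sapiens) for inhibition, read by MTT assay, with a stated time of 72 h (on this read-out higher numbers stand for weaker inhibition and lower numbers for stronger inhibition), compound 1 gives 35200 nM, the highest number of the three measured compounds. Compound 2 `Cc1cc(N2CC[C@@H](C)[C@@H](N(C)c3ncnc4[nH]ccc34)C2)n2nc(SCCc3ccccc3)nc2n1` gives 11800 nM, and compound 3 `Cc1cc(N2CC[C@@H](C)[C@@H](N(C)c3ncnc4[nH]ccc34)C2)n2nc(SCc3ccc([N+](=O)[O-])cc3)nc2n1` gives 29400 nM. The move to compound 4 `COc1ccc(CSc2nc3nc(C)cc(N4CC[C@@H](C)[C@@H](N(C)c5ncnc6[nH]ccc56)C4)n3n2)cc1` is 4-methoxyphenyl in place of vinyl on a saturated chain carbon bound to a sulfur. Among the measured compounds shown here, two measured steps bear on it. Benzyl in place of vinyl brought a 3.0-fold lower number from compound 1 to compound 2 (0.47 log units; beyond the scatter), whereas 4-nitrophenyl in place of vinyl brought only a 1.2-fold lower number from compound 1 to compound 3 (0.08 log units; within the scatter). Since 4-methoxyphenyl shares the six-membered aromatic ring of the benzyl case, a modest drop in the number is expected, a 2.5-fold lower number from compound 1 to compound 4 (0.40 log units; beyond the scatter). Compound 4 is therefore estimated at 14000 nM, with a likely range from 6000 nM to 35000 nM.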

Compound 4, half-maximal inhibitory concentration: 18200 nM
Estimate against measurement, compound 4: 1.3-fold (0.11 log units) below; the measured number falls inside the stated range.
By their numbers in this assay, from the lowest: compounds 2, 4, 3 and 1 (each within the scatter of the next, the first and the last beyond it).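

In this assay the change from allyl to 4-methoxybenzyl on the sulfur gives a 1.9-fold lower number from compound 1 to compound 4 (0.29 log units; within the scatter) and so cannot be told apart from the original group. Methoxy in place of nitro on an aromatic carbon, the first change made on the ring itself, gives a 1.6-fold lower number from compound 3 to compound 4 (0.21 log units; within the scatter) and 4-methoxyphenyl in place of benzyl gives a 1.5-fold higher number from compound 2 to compound 4 (0.19 log units; within the scatter) and both stay within the scatter. Compound 4 therefore cannot be ranked against any of the other three compounds. No measurement here explains these numbers. From the compounds shown here alone, whether an amine or a carboxylic acid on that ring would shift the number beyond the scatter stays open.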